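The compounds below may be only part of what the source reports. "The series", "measured", "known", "first", "only" and "open" are said of these compounds alone.

Measured compounds:
compound 1 `CC(C)(C)c1ccc(OC(C)(C)C2OCC(C/C=C\CCC(=O)O)C(c3cccnc3)O2)cc1`: 280 nM
compound 2 `Cc1ccc(SC(C)(C)C2OCC(C/C=C\CCC(=O)O)C(c3cccnc3)O2)c([N+](=O)[O-])c1`: 30 nM

Among the measured compounds shown here, in an assay for inhibition of Thromboxane-A synthase (Homo sapiens), using microsomes (a lower number here means a stronger inhibitor, a higher number a weaker inhibitor), compound 2 gives 30 nM, the lowest number among the two measured compounds; compound 1 gives 280 nM, and the only measured step is a 9.3-fold lower number from compound 1 to compound 2 (0.97 log units; beyond the scatter). Compound 3 `CC(C)(Cc1ccccc1)C1OCC(C/C=C\CCC(=O)O)C(c2cccnc2)O1` is not yet measured. It differs from compound 2 in one place: a group of 7 heavy atoms (7 carbon; one six-membered aromatic ring of carbon only) in place of a group of 11 heavy atoms (7 carbon, 1 nitrogen, 2 oxygen, 1 sulfur; one six-membered aromatic ring of carbon only), on a saturated chain carbon bound to two saturated chain carbons and a saturated ring carbon. For the measured compounds named here, the one measured step on this carbon, a 9.3-fold lower number from compound 1 to compound 2 (0.97 log units; beyond the scatter), shows that exchanging the group there can shift the number beyond the scatter, but it compared two groups of 11 heavy atoms and neither was benzyl, so it sets no direction for this change. With benzyl in place of the group that leaves, a number higher than that of compound 2 is expected, nearer the value of compound 1. Compound 3 is expected to give about 200 nM, within 50 nM to 800 nM. This expected step, a 6.7-fold higher number from compound 2 to compound 3 (0.82 log units; beyond the scatter), is an estimate rather than a measurement.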

Compound 3, half-maximal inhibitory concentration: 12 nM
The estimate for compound 3 lay 17-fold (1.22 log units) above the measured number, and the stated range ends above it.
By their numbers in this assay, from the lowest: compound 3; then compound 2; then compound 1.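

In this assay, benzyl on this saturated chain carbon gives a 2.5-fold lower number from compound 2 to compound 3 (0.40 log units; beyond the scatter) and a 23-fold lower number from compound 1 to compound 3 (1.37 log units; beyond the scatter), so compound 3 has the lowest number of the three. Among the compounds shown here, the earlier step compared only two groups of 11 heavy atoms, whereas this result shows that a group of 7 heavy atoms with no hydrogen-bond acceptors can give a lower number than either of them. No supporting evidence is available to explain this result.

The compounds shown leave open whether the aromatic ring of benzyl is needed at all, which a cyclohexylmethyl group would address. They also leave open whether a longer chain such as 2-phenylethyl, or a benzyl group carrying a nitro or tert-butyl substituent, would lower the number further or raise it.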